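The compounds below may be only part of what the source reports. "The series", "measured", "known", "first", "only" and "open" are said of these compounds alone.

Compound 1 `Cc1ccc(C2C(C#N)=C(N)N(c3ccc(S(N)(=O)=O)cc3)C3=C2CCCC3)cc1` gives 90% in a functional assay on Ehrlich cells (Mus musculus) for cytotoxicity, read by trypan blue exclusion, with a stated time of 2 h, tested at 100 ug/mL; on this read-out higher numbers stand for a stronger effect at the one concentration tested and lower numbers for a weaker effect. Compound 2 `N#CC1=C(N)N(c2ccc(S(N)(=O)=O)cc2)C2=C(CCCC2)C1/C=C/c1ccccc1` gives 70% in this assay, the step being a number 20 percentage points lower from compound 1 to compound 2 (beyond the scatter). Compound 3 `N#CC1=C(N)N(c2ccc(S(N)(=O)=O)cc2)C2=C(CCCC2)C1c1ccccc1Cl` gives 10% in this assay, the lowest of the three numbers, reached by a number 80 percentage points lower from compound 1 to compound 3 (beyond the scatter) and by a number 60 percentage points lower from compound 2 to compound 3 (beyond the scatter). Compound 4 `N#CC1=C(N)N(c2ccc(S(N)(=O)=O)cc2)C2=C(CCCC2)C1c1ccc(Cl)cc1Cl` differs from compound 3 by chloro in place of hydrogen on an aromatic carbon. Among the compounds with values here, no measured step exchanges hydrogen for chloro; the three steps seen all swap the whole group on the saturated ring carbon and move the read-out by large amounts, so they show only that this group matters and give no direct guide. Compound 4 is therefore expected to stay close to compound 3, with a number 5 percentage points higher from compound 3 to compound 4 (within the scatter) judged to lie within the scatter. The estimate for compound 4 in this assay is 15%, between 0% and 45%.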

Compound 4, a percentage reported as activity, at one concentration (the size of the read-out at that concentration, not a potency): 70%
For compound 4 the middle estimate is 55 percentage points below the measured one; the whole stated range lies below it.
By their numbers in this assay, from the lowest: compound 3; then compounds 2 and 4 (each within the scatter of the next); then compound 1.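

In this assay, chloro in place of hydrogen, on the aromatic carbon para to the large group, gives a number 60 percentage points higher from compound 3 to compound 4 (beyond the scatter), so one chlorine atom at this place produces a large step, which earlier only whole-group exchanges had done. Compared with other groups on the saturated ring carbon, 2,4-dichlorophenyl gives no change at the digits printed from compound 2 to compound 4 (within the scatter) and a number 20 percentage points lower from compound 1 to compound 4 (beyond the scatter). No measured evidence accounts for these steps. Open, as far as these compounds go, is whether an amine or a methoxy group on that same aromatic carbon would give a similar step, and what 4-chlorophenyl alone would give.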